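Naphthyl thiazolidinedione amides: anilide swap to nitrophenyl

The compounds below may be only part of what the source reports. "The series", "measured", "known", "first", "only" and "open" are said of these compounds alone.

Within the data shown here, compound 1 `COc1cccc(NC(=O)COc2ccc3cc(/C=C4/SC(=O)NC4=O)ccc3c2)c1` is the only member of this series with a number in hand: in an assay on isolated protein for inhibition of histone deacetylase 8 (Homo sapiens), with a stated time of 1 h (a higher number here means a weaker inhibitor, a lower number a stronger inhibitor), compound 1 gives 7600 nM. Compound 2 `O=C(COc1ccc2cc(/C=C3/SC(=O)NC3=O)ccc2c1)Nc1ccccc1Oc1ccccc1` returns only a limit in this assay, > 50000 nM, so no number is known for compound 2. No step between two measured compounds is shown, so nothing in the data yet sizes any change at the amide-type nitrogen.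

Compound 3 `O=C(COc1ccc2cc(/C=C3/SC(=O)NC3=O)ccc2c1)Nc1ccc([N+](=O)[O-])cc1` differs from compound 1 by 4-nitrophenyl in place of 3-methoxyphenyl on an amide-type nitrogen. Among the measured compounds shown here, with no measured step to lean on, the expectation for compound 3 is a change of modest size at most, in no firm direction, likely within the scatter of this assay relative to compound 1. Compound 3 is therefore estimated at 10000 nM, with a range from 3000 nM to 40000 nM, which corresponds to an expected step of a 1.3-fold higher number from compound 1 to compound 3 (0.12 log units; within the scatter).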

Compound 3, half-maximal inhibitory concentration: 4000 nM
Compound 3: the middle estimate sits 2.5-fold (0.40 log units) above what was measured; measured number inside the range.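

In this assay, among these compounds, 4-nitrophenyl in place of 3-methoxyphenyl on the amide-type nitrogen gives a 1.9-fold lower number from compound 1 to compound 3 (0.28 log units; within the scatter), the first sized step at this position. This assay therefore does not separate these two groups, although they differ in both substituent and its numbered place on the ring, so the step cannot be assigned to either difference alone. Among the compounds shown here, compound 2 remains a limit and not a number, so no step to it can be read: the limit of > 50000 nM in this assay, at which 1 of the 3 values shown sits.

Unsubstituted phenyl, 4-methoxyphenyl and 3-nitrophenyl would separate substituent from place, and a cyclohexyl group or a longer alkyl chain on the amide-type nitrogen would test whether the aromatic ring is needed. Nothing shown sizes a change in the rest of the shared core.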